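Swapping an amide for a urea on a shared core

A few compounds are considered here, and "the series" means these few. Any claim that something is new, unique, unknown or untested is made for them only; others in the source may bear on it.

Of the compounds shown here, two with a shared core have been tested in an assay on isolated protein for inhibition of Gonadotropin-releasing hormone receptor (Homo sapiens); a higher number here means a weaker inhibitor, a lower number a stronger inhibitor. Compound 1 `COc1ccc([N+](=O)[O-])cc1CSc1nc2cc(NC(=O)NC(C)(C)C)ccc2n1-c1ccccc1` gives 350 nM. Compound 2 `COc1ccc([N+](=O)[O-])cc1CSc1nc2cc(NC(=O)C(C)(C)C)ccc2n1C(C)C` gives 180 nM. The two numbers lie within the usual scatter of each other, so neither compound can be called the stronger inhibitor. Among the measured compounds shown here, compound 1 and compound 2 differ in two places at once, and no single step between them can be read off.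

Compound 3 `COc1ccc([N+](=O)[O-])cc1CSc1nc2cc(NC(=O)NC(C)(C)C)ccc2n1C(C)C` has not yet been measured in this assay. It differs from compound 2 in one place: (tert-butyl)amino in place of tert-butyl on a carbonyl carbon. Compound 1 already carries this same (tert-butyl)amino group, and its value is close to that of compound 2, which suggests that this change on its own does little. The step from compound 2 to compound 3 is therefore expected to be a 1.4-fold higher number from compound 2 to compound 3 (0.14 log units; within the scatter), that is, no step beyond the scatter in either direction. Compound 3 is estimated at 250 nM, with a range from 100 nM to 600 nM.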

Compound 3, half-maximal inhibitory concentration: 62 nM
Beside the measured number, compound 3's estimate is 4.0-fold (0.61 log units) above it; the whole stated range lies above it.
By their numbers in this assay, from the lowest: compound 3; then compounds 2 and 1 (each within the scatter of the next).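

In this assay, replacing tert-butyl with (tert-butyl)amino on a carbonyl carbon gives a 2.9-fold lower number from compound 2 to compound 3 (0.46 log units; beyond the scatter), so this change has a real effect when isopropyl sits on the aromatic nitrogen, which the earlier pair, differing in two places at once, could not show. Isopropyl in place of phenyl on the aromatic nitrogen gives a 5.6-fold lower number from compound 1 to compound 3 (0.75 log units; beyond the scatter), so the close values of compound 1 and compound 2 concealed two separate steps running in opposite directions. Nothing available here explains either step.

On these data alone, it remains open whether the (tert-butyl)amino step keeps its size when phenyl sits on the aromatic nitrogen. Also open, as far as these compounds go, is how methylamino or dimethylamino on the carbonyl carbon would compare with (tert-butyl)amino, and how ethyl on the aromatic nitrogen would compare with isopropyl.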